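Shortening the Long Chain of Compound 2

The source may hold more compounds than are shown below. What is called first, only, known or untested is meant among the compounds shown, and "the series" means these compounds.

In a functional assay on HeLa cells (Homo sapiens) for cytotoxicity, read by MTT assay, with a stated time of 24 h (on this read-out higher numbers stand for weaker inhibition and lower numbers for stronger inhibition), compound 2 `CCCCCCCC/C=C\CCCCCCCC(=O)Nc1nnc(S[C@@H]2O[C@H](COC(C)=O)[C@H](OC(C)=O)[C@H](OC(C)=O)[C@H]2OC(C)=O)s1` gives 54400 nM. This lies within the scatter of compound 3 `C=CCCCCCCCCC(=O)Nc1nnc(S[C@@H]2O[C@H](CO)[C@H](O)[C@H](O)[C@H]2O)s1` at 58300 nM, while compound 1 `CCCCCCCCCCCCCCCCCC(=O)Nc1nnc(S[C@@H]2O[C@H](CO)[C@H](O)[C@H](O)[C@H]2O)s1` has the lowest number, 11200 nM. Compound 4 `CCCCCCCC(=O)Nc1nnc(S[C@@H]2O[C@H](COC(C)=O)[C@H](OC(C)=O)[C@H](OC(C)=O)[C@H]2OC(C)=O)s1` differs from compound 2 by hydrogen in place of dec-1-en-1-yl on a saturated chain carbon, seven bonds along the chain from a carbonyl carbon. One measured step also shortens the chain, a 5.2-fold higher number from compound 1 to compound 3 (0.72 log units; beyond the scatter), although that pair lacks the acetyl groups of compound 2. A move of similar size towards a higher number is therefore expected in this assay. The expected change is a 2.2-fold higher number from compound 2 to compound 4 (0.34 log units; beyond the scatter). Compound 4 is estimated at 120000 nM, with an expected range of 50000 nM to 300000 nM.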

Compound 4, half-maximal inhibitory concentration: 43600 nM
The estimate for compound 4 lay 2.8-fold (0.44 log units) above the measured number; the measured number lies below the stated range.
By their numbers in this assay, from the lowest: compound 1; then compounds 4, 2 and 3 (each within the scatter of the next).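

In this assay the change on this saturated chain carbon, seven bonds along the chain from a carbonyl carbon, gives a 1.2-fold lower number from compound 2 to compound 4 (0.10 log units; within the scatter) with the acetyl groups in place, so losing dec-1-en-1-yl moves the number no further than the scatter. The shortening without acetyl groups gives a 5.2-fold higher number from compound 1 to compound 3 (0.72 log units; beyond the scatter) and lies beyond the scatter, so that size of step did not carry over to this pair. No evidence on the reason is at hand.

Still open, on these data alone, is whether an amine or a carboxylic acid in place of dec-1-en-1-yl here would stay within the scatter of compound 2. Also open, as far as these compounds go, is how a longer chain than that of compound 2 would read with the acetyl groups in place.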